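Amino substitution on the aryl group of compound 2

The compounds below may be only part of what the source reports. "The series", "measured", "known", "first", "only" and "open" are said of these compounds alone.

The study starts from compound 1 `Cc1nn(C)c2c(O)ncnc12`, which in an assay on membranes from brain for binding affinity to adenosine receptor A1 (Rattus norvegicus), read by radioligand binding (on this read-out higher numbers stand for weaker inhibition and lower numbers for stronger inhibition), gives 20100 nM. Compound 2 `Cc1nn(C)c2c(O)nc(-c3ccccc3)nc12` carries a phenyl group on the shared core and in this assay gives 1020 nM. Among the measured compounds shown here, the only measured step, a 20-fold lower number from compound 1 to compound 2 (1.29 log units; beyond the scatter), is large. Compound 2 thus stands at the lowest of the two numbers measured, and the nearest one, compound 1, lies well beyond the scatter. Compound 3 `Cc1nn(C)c2c(O)nc(-c3ccc(N)cc3)nc12` has not yet been measured; it differs from compound 2 by amino in place of hydrogen on an aromatic carbon. For the measured compounds named here, no measured step bears directly on this change: the one step known concerns the phenyl group itself, not a substituent on it. The account therefore expects for compound 3 a modest step, a 1.7-fold lower number from compound 2 to compound 3 (0.23 log units; within the scatter), not clearly beyond the scatter. Compound 3 is estimated at 600 nM, in a range from 150 nM to 3000 nM.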

Compound 3, half-maximal inhibitory concentration: 380 nM
Compound 3: middle estimate off by 1.6-fold (0.20 log units), on the high side; the measured number falls inside the stated range.
By their numbers in this assay, from the lowest: compound 3; then compound 2; then compound 1.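

Among the compounds shown here, until now, the compounds showed only that adding a phenyl group to the shared core lowers the number in this assay, and they said nothing about a substituent on that phenyl group. An amino group added to the phenyl group, para to a large group, gives a 2.7-fold lower number from compound 2 to compound 3 (0.43 log units; beyond the scatter) and thus shows that this place on the phenyl group can take a small substituent while the number still falls by a modest step beyond the scatter. Nothing available here explains this step.

The compounds shown leave open whether a hydroxyl group, a methoxy group or a carboxylic acid at this place would move the number in the same direction. They also leave open whether a longer amine at this place, or an amino group elsewhere on the phenyl group, would match this step.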